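Succinimide to Thiazolidinedione on the Benzylidene Arm

The source may hold more compounds than are shown below. What is called first, only, known or untested is meant among the compounds shown, and "the series" means these compounds.

Compound 1 `CCc1cnc(N2CCC(c3nc(COc4ccc(/C=C5\CC(=O)NC5=O)cc4F)cs3)CC2)nc1`: 49 nM
Compound 2 `CCc1cnc(N2CCC(c3nc(COc4ccc(/C=C5\CC(=O)N(CCN)C5=O)cc4F)cs3)CC2)nc1`: "not determined" (no result reported)

In a functional assay on cells for agonist activity at Glucose-dependent insulinotropic receptor (Homo sapiens), read by a luciferase reporter, with a stated time of 6 h (on this read-out lower numbers stand for an effect already at smaller amounts and higher numbers for an effect only at larger amounts of compound), compound 1 gives 49 nM. Compound 2 carries an aminoethyl group on the imide nitrogen, and in this assay compound 2 stands at "not determined" (no result reported), so its standing cannot be placed. Compound 3 `CCc1cnc(N2CCC(c3nc(COc4ccc(/C=C5\SC(=O)NC5=O)cc4F)cs3)CC2)nc1` differs from compound 2 by a group of 8 heavy atoms (4 carbon, 1 nitrogen, 2 oxygen, 1 sulfur; one five-membered non-aromatic ring with 2 hetero atoms) in place of a group of 11 heavy atoms (7 carbon, 2 nitrogen, 2 oxygen; one five-membered non-aromatic ring with 1 hetero atom), on an aromatic carbon. Among the measured compounds shown here, with no measured step to lean on, the expectation rests on compound 1 alone, and the change is expected to move potency by no more than the usual scatter. Compound 3 is estimated at 60 nM, within 15 nM to 250 nM.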

Compound 3, half-maximal effective concentration: 780 nM
Beside the measured number, compound 3's estimate is 13-fold (1.11 log units) below it; the measured number lies above the stated range.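

In this assay, the ring with 2 hetero atoms, one of them sulfur, in place of the ring with 1 hetero atom gives a 16-fold higher number from compound 1 to compound 3 (1.20 log units; beyond the scatter). The group on this aromatic carbon is therefore not freely exchangeable, even between two rings with the same heavy-atom count. No measurement shown here explains the loss.

Going by these compounds, whether a hydantoin or oxazolidinedione ring at this position would behave like compound 1 or like compound 3 remains open. The aminoethyl group on the imide nitrogen also cannot be judged, since compound 2 has no number.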